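The source may hold more compounds than are shown below. What is called first, only, known or untested is meant among the compounds shown, and "the series" means these compounds.

Two sulfonamides sharing one core have been measured in a functional assay for inhibition; on this read-out lower numbers stand for stronger inhibition and higher numbers for weaker inhibition. Compound 1 `O=[N+]([O-])c1ccc(S(=O)(=O)Nc2cc(F)c(O)c(F)c2)cc1` gives 45700 nM in this assay. Compound 2 `COc1ccc(C(=O)Nc2ccc(S(=O)(=O)Nc3cc(F)c(O)c(F)c3)cc2)cc1`, the other measured analogue, gives 70700 nM in this assay; the two numbers lie within the usual scatter of each other, so neither compound can be called the stronger inhibitor on this evidence. Compound 3 `O=S(=O)(Nc1cc(F)c(O)c(F)c1)c1ccc(C(F)(F)F)cc1` has not yet been measured. It differs from compound 1 in one place: trifluoromethyl in place of nitro on an aromatic carbon. Among the compounds with values here, no measured pair in this set shows what such an exchange does, so the expectation for compound 3 rests only on the weak inhibition seen for compound 1 and compound 2. The step from compound 1 to compound 3 is expected to be small, a 1.2-fold higher number from compound 1 to compound 3 (0.08 log units; within the scatter), and not clearly beyond the scatter in either direction. Compound 3 is therefore estimated at 55000 nM in this assay, with a plausible range from 20000 nM to 150000 nM.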

Compound 3, half-maximal inhibitory concentration: 66000 nM
The estimate for compound 3 lay 1.2-fold (0.08 log units) below the measured number; the measured number falls inside the stated range.
By their numbers in this assay, from the lowest: compounds 1, 3 and 2 (each within the scatter of the next).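

Trifluoromethyl in place of nitro, on an aromatic carbon para to a large group, gives the first step at this position that can be read in this assay: a 1.4-fold higher number from compound 1 to compound 3 (0.16 log units; within the scatter). Nitro brings hydrogen-bond acceptors and trifluoromethyl brings none, yet the exchange of one for the other stays within the scatter, so this difference in the counted groups has no visible effect on the read-out here, and inhibition remains weak. Nothing on hand explains this outcome.

Going by these compounds, it remains open whether an amine, a carboxylic acid or a longer chain on this aromatic carbon would shift the number beyond the scatter in either direction. On these data alone, it is equally open whether any change elsewhere on the shared core would do so.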